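The compounds below may be only part of what the source reports. "The series", "measured", "known", "first", "only" and "open" are said of these compounds alone.

In a functional assay on UACC-257 cells (Homo sapiens) for cytotoxicity, read by sulforhodamine B assay, with a stated time of 48 h (a higher number here means that more compound is tolerated, a lower number that less compound is tolerated), compound 1 `ClCc1ccccc1Cn1cnc2c(Cl)nc(Cl)nc21` gives 8510 nM. Compound 2 `ClCc1ccccc1Cn1cnc2c(Cl)ncnc21` differs from compound 1 by one change, (chloro in place of hydrogen on an aromatic carbon), and in this assay compound 2 gives 66100 nM. That single change made the step of a 7.8-fold lower number from compound 2 to compound 1 (0.89 log units; beyond the scatter). Compound 3 `ClCc1cccc(Cn2cnc3c(Cl)ncnc32)c1` gives 67600 nM; its value and that of compound 2 lie within the usual scatter of each other, so the two cannot be told apart on these numbers. The difference between the cores of compound 2 and compound 3 is not broken down here.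

Compound 4 `ClCc1cccc(Cn2cnc3c(Cl)nc(Cl)nc32)c1` has not yet been measured. It stands to compound 3 as compound 1 stands to compound 2: the change is chloro in place of hydrogen on an aromatic carbon, the same change in the same surroundings. Because the earlier step was a 7.8-fold lower number from compound 2 to compound 1 (0.89 log units; beyond the scatter), the expected step is a 7.5-fold lower number from compound 3 to compound 4 (0.88 log units; beyond the scatter). Within the data shown here, only one earlier example of this change exists, so the expectation rests on a single case and carries its own uncertainty. Compound 4 is therefore estimated at 9000 nM, with a likely range from 3000 nM to 27000 nM.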

Compound 4, concentration lethal to 50% of the cells: 6450 nM
Beside the measured number, compound 4's estimate is 1.4-fold (0.14 log units) above it; the range from low to high includes it.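

In this assay, chloro in place of hydrogen on the aromatic carbon between two ring nitrogen atoms gives a 10-fold lower number from compound 3 to compound 4 (1.02 log units; beyond the scatter). Set beside the earlier example, the step carries over from one core to the other with no size difference that can be told apart: the same change on two cores in this assay, a 7.8-fold lower number (0.89 log units; beyond the scatter) from compound 2 to compound 1 and a 10-fold lower number (1.02 log units; beyond the scatter) from compound 3 to compound 4, 1.3-fold (0.13 log units) apart, within the scatter of two such steps. This shows that the change lowered the number on both cores tested, but two pairs in a single assay do not show that it would do the same on any other core, and they do not explain why the number falls.

All the compounds shown have either hydrogen or chloro on that carbon, which leaves open whether an amine, a methoxy group or a longer carbon chain there would lower the number as well. Every compound shown also keeps its other chloro group on the same ring, and what an amine in that other place would do remains open too.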